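The source may report more compounds than this note shows. Statements on the series, on what has been measured and on what is new or still open speak of the compounds shown alone.

Measured compounds:

Compound 1, `CCCCCC1(O)C(=O)Nc2ccc(Nc3ccc(C)cc3)cc21` — 8100 nM
Compound 2, `Cc1ccc(Nc2ccc3c(c2)C(O)(CCC(C)C)C(=O)N3)cc1` — 12500 nM
Compound 3, `CCCCCC1(O)C(=O)Nc2ccc(Nc3ccc(Cl)cc3)cc21` — 1900 nM

In a functional assay on A549 cells (Homo sapiens) for antiproliferative activity, read by MTT assay, with a stated time of 48 h (a lower number here means a stronger inhibitor, a higher number a weaker inhibitor), compound 1 gives 8100 nM. Compound 2 differs from it by isopropyl in place of propyl on a saturated chain carbon, two bonds along the chain from a saturated ring carbon and gives 12500 nM; the step is a 1.5-fold higher number from compound 1 to compound 2 (0.19 log units; within the scatter), so the two values cannot be told apart. The difference from compound 1 to compound 3 is chloro in place of methyl on an aromatic carbon, and compound 3 gives 1900 nM; here the step is a 4.3-fold lower number from compound 1 to compound 3 (0.63 log units; beyond the scatter). Compound 3 thus has the lowest number of the three, with compound 1 nearest and compound 2 furthest, both gaps beyond the scatter.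

Compound 4, `CC(C)CCC1(O)C(=O)Nc2ccc(Nc3ccc(Cl)cc3)cc21`, has not been measured in this assay. It differs from compound 3 by isopropyl in place of propyl on a saturated chain carbon, two bonds along the chain from a saturated ring carbon. Going by the values given here, this is the same change as the one from compound 1 to compound 2, made at the same place in the chain, while the two cores differ by chloro in place of methyl on an aromatic carbon. Since that earlier change produced a 1.5-fold higher number from compound 1 to compound 2 (0.19 log units; within the scatter), the step from compound 3 to compound 4 is expected to be small as well, and it is expected to fall within the scatter. The expected step is a 1.5-fold higher number from compound 3 to compound 4 (0.17 log units; within the scatter), resting on a 1.5-fold higher number from compound 1 to compound 2 (0.19 log units; within the scatter). Compound 4 is therefore estimated to give 2800 nM in this assay, with a likely range from 1200 nM to 7000 nM.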

Compound 4, half-maximal inhibitory concentration: 2700 nM
Compound 4: the middle estimate sits 1.0-fold (0.02 log units) above what was measured; low and high end bracket the measured number.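

In this assay, isopropyl in place of propyl on the core of compound 3 gives a 1.4-fold higher number from compound 3 to compound 4 (0.15 log units; within the scatter), so these two values cannot be told apart, and the chain change reads the same on both cores: the same change on two cores in this assay, a 1.5-fold higher number (0.19 log units; within the scatter) from compound 1 to compound 2 and a 1.4-fold higher number (0.15 log units; within the scatter) from compound 3 to compound 4, 1.1-fold (0.04 log units) apart, within the scatter of two such steps

Chloro in place of methyl, read with the isopropyl-ended chain, gives a 4.6-fold lower number from compound 2 to compound 4 (0.67 log units; beyond the scatter), a step beyond the scatter that matches the one seen with the propyl-ended chain: the same change on two cores in this assay, a 4.3-fold lower number (0.63 log units; beyond the scatter) from compound 1 to compound 3 and a 4.6-fold lower number (0.67 log units; beyond the scatter) from compound 2 to compound 4, 1.1-fold (0.04 log units) apart, within the scatter of two such steps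

Within these four compounds, then, each change carries from one core to the other, and the two changes behave as independent of each other; this rests on only two pairs per change in a single cell assay, so it does not show that the same would hold on any other core, and it gives no reason for the gain seen with chloro.

The compounds shown leave open whether other groups on that aromatic carbon, such as fluoro, bromo, methoxy or a nitrile, would follow chloro. They also leave open how a longer chain, or a chain ending in an amine or a carboxylic acid, would compare with the propyl-ended and isopropyl-ended chains.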